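Swapping 2-Hydroxyphenyl for 4-Hydroxyphenyl on a Shared Core

The compounds below may be only part of what the source reports. "The series", "measured", "known", "first", "only" and "open" are said of these compounds alone.

Compound 1 `Oc1cccc(-c2cc(-c3cccc(O)c3)nc(-c3ccccc3O)c2)c1` was tested in a functional assay on DU-145 cells (Homo sapiens) for cytotoxicity, read by CCK-8 assay, with a stated time of 4 days (on this read-out lower numbers stand for stronger inhibition and higher numbers for weaker inhibition), and reached only the limit > 50000 nM. Compound 3 `Oc1ccc(-c2cc(-c3cccc(O)c3)cc(-c3cccc(O)c3)n2)cc1` gives 1940 nM in this assay. The step between them, an at least 25-fold lower number from compound 1 to compound 3 (1.41 log units; beyond the scatter), rests on a single change, (4-hydroxyphenyl in place of 2-hydroxyphenyl on an aromatic carbon). Compound 2 `Oc1ccccc1-c1cc(-c2ccccc2O)nc(-c2ccccc2O)c1` gives 5040 nM in this assay, a higher number than compound 3; the difference between the cores of compound 1 and compound 2 is not broken down here. Compound 4 `Oc1ccc(-c2cc(-c3ccccc3O)cc(-c3ccccc3O)n2)cc1` is not yet measured and differs from compound 2 by 4-hydroxyphenyl in place of 2-hydroxyphenyl on an aromatic carbon. This is the same kind of change as from compound 1 to compound 3, though there the place was meta to two 3-hydroxyphenyl groups, whereas here it is meta to two 2-hydroxyphenyl groups. Given the large drop seen in an at least 25-fold lower number from compound 1 to compound 3 (1.41 log units; beyond the scatter), a lower number is expected for compound 4, with an expected step of a 5.0-fold lower number from compound 2 to compound 4 (0.70 log units; beyond the scatter). Compound 4 is estimated at 1000 nM in this assay, between 300 nM and 4000 nM.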

Compound 4, half-maximal inhibitory concentration: 360 nM
Compound 4: middle estimate off by 2.8-fold (0.44 log units), on the high side, within the range that was stated.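

In this assay, 4-hydroxyphenyl in place of 2-hydroxyphenyl again gave a large step on a second core, a 14-fold lower number from compound 2 to compound 4 (1.15 log units; beyond the scatter). The direction of the change therefore carried over between these two cores, and the sizes can be set side by side only with caution: the same change on two cores in this assay, an at least 25-fold lower number (1.41 log units; beyond the scatter) from compound 1 to compound 3 and a 14-fold lower number (1.15 log units; beyond the scatter) from compound 2 to compound 4; the limit leaves it open whether they differ. It does not show that the size of the step carries over, since compound 1 reached only a limit and gives no number for the first step: the limit of > 50000 nM in this assay, at which 1 of the 4 values shown sits.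

The compounds shown leave open whether the step would persist with a methoxy group or an amine in place of the hydroxyl on the entering ring. They also leave open whether it would hold on a core carrying neither 2-hydroxyphenyl nor 3-hydroxyphenyl groups.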